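The compounds below may be only part of what the source reports. "The series", "measured", "known", "first", "only" and "open" are said of these compounds alone.

Values in a functional assay on MGC-803 cells (Homo sapiens) for inhibition, read by MTT assay, with a stated time of 72 h (on this read-out lower numbers stand for stronger inhibition and higher numbers for weaker inhibition), so far:
Compound 1 (`O=C(NCc1ccc(NC(=O)c2cc(-c3ccccc3)ccc2N2CCCC2)cc1)OCc1cccnc1`) gives 10500 nM as a number.
Compound 2 (`O=C(NCc1ccc(NC(=O)c2cccc(F)c2N2CCCC2)cc1)OCc1cccnc1`) gives > 100000 nM as a limit.
Compound 3 (`Cc1cccc(C(=O)Nc2ccc(CNC(=O)OCc3cccnc3)cc2)c1N1CCCC1`) gives > 100000 nM as a limit.

Among the measured compounds shown here, compound 1 holds the only number, and the rest is summed up by the limit of > 100000 nM in this assay, at which 2 of the 3 values shown sit, in plain terms. Compound 4 (`O=C(NCc1ccc(NC(=O)c2cc(Cl)ccc2N2CCCC2)cc1)OCc1cccnc1`) is the open case. Its change from compound 1 is chloro in place of phenyl on an aromatic carbon, counted in full as chloro in place of phenyl on an aromatic carbon here.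

For the measured compounds named here, the one measured step is a step that the two limits leave unreadable from compound 2 to compound 3 and gives no size to carry over. Neither compound 2 nor compound 3 carries phenyl, and neither is an exact match for this change. Among the three measured compounds, the one with phenyl is the one with a number, and none goes against that, though this is a thin base. The expectation therefore starts from compound 1 at 10500 nM and points toward weaker inhibition in this assay. Compound 4 is also expected to have some chance of giving a limit rather than a number. The expected size is a 4.3-fold higher number from compound 1 to compound 4 (0.63 log units; beyond the scatter) on this reading. For compound 4 the estimate is 45000 nM with an expected range from 10000 nM to 100000 nM in this series.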

Compound 4, half-maximal inhibitory concentration: 55500 nM
Compound 4: the middle estimate sits 1.2-fold (0.09 log units) below what was measured, and the stated range covers the measured number.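

In this assay, among the compounds shown here, chloro in place of phenyl on the aromatic carbon para to a pyrrolidin-1-yl group gives a 5.3-fold higher number from compound 1 to compound 4 (0.72 log units; beyond the scatter), the first readable step and one that is modest but beyond the scatter. For the compounds shown here, compound 4 still gives a number, 55500 nM, so the phenyl group is not required for a number in this assay, and compound 1 no longer stands alone as the only compound with one. The remaining compounds stay as limits of the assay and add no size to this comparison: the limit of > 100000 nM in this assay, at which 2 of the 4 values shown sit.

With only phenyl and chloro compared on this carbon, the data cannot separate the loss of the six-membered aromatic ring from the entry of chlorine, or show whether the step follows the drop in heavy atoms. As far as these compounds go, how a methoxy group or an amine on the same carbon would read in this assay stays open, as does whether any group there could give a lower number than compound 1 at 10500 nM.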